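This account rests on a few compounds, and the source may have more. Where it says the series, first, only, none or still open, it means among the compounds named here.

Measured in a physicochemical assay for solubility (on this read-out lower numbers stand for lower solubility and higher numbers for higher solubility), so far:

Compound 1 `C[C@H](Oc1ccc(S(C)(=O)=O)cc1C(=O)N1Cc2ccccc2C1)C(F)(F)F` gives < 1 ug/mL (a limit of the assay)
Compound 2 `Cc1cccc2c1CN(C(=O)c1cc(S(C)(=O)=O)ccc1O[C@@H](C)C(F)(F)F)C2` gives 73 ug/mL
Compound 3 `C[C@H](Oc1ccc(S(C)(=O)=O)cc1C(=O)N1Cc2cc(C(F)(F)F)cnc2C1)C(F)(F)F` gives 280 ug/mL

Compound 1 has no exact number, only a limit, and it stands at the bottom of the series: the limit of < 1 ug/mL in this assay, at which 1 of the 3 values shown sits. Compound 4 `C[C@H](Oc1ccc(S(C)(=O)=O)cc1C(=O)N1Cc2ccc(-c3ccccn3)cc2C1)C(F)(F)F` keeps the core of compound 1 and carries pyridin-2-yl in place of hydrogen on an aromatic carbon .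

Among the compounds with values here, the only measured step of a similar kind is an at least 73-fold higher number from compound 1 to compound 2 (1.86 log units; beyond the scatter), for methyl in place of hydrogen on an aromatic carbon. Within the data shown here, compound 3 gives 280 ug/mL, but no single-place step ties it to the other compounds, so it offers only a further value.

On the strength of compound 2 and its 73 ug/mL, a clear rise in this assay is expected for compound 4. The expected rise is probably smaller than that single step, since the group that enters is a different and much larger one, and the evidence is one step starting from a limit. For compound 4 the estimated value is 15 ug/mL, with an expected range from 1.5 ug/mL to 150 ug/mL. This estimate amounts to an expected at least 15-fold higher number from compound 1 to compound 4 (1.17 log units; beyond the scatter).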

Compound 4, solubility: 30 ug/mL
Beside the measured number, compound 4's estimate is 2.0-fold (0.30 log units) below it; the range from low to high includes it.
By their numbers in this assay, from the lowest: compound 4; then compound 2; then compound 3. At a limit, below all of these: compound 1.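

In this assay, the step of an at least 30-fold higher number from compound 1 to compound 4 (1.47 log units; beyond the scatter) shows that the earlier rise was not confined to methyl: a single pyridin-2-yl, a far larger group of 6 heavy atoms with a hydrogen-bond acceptor, also gives a large step beyond the scatter. It also adds a second place on the core of compound 1, since this group sits on an aromatic carbon meta to a fused ring and para to a fused ring, which is not the carbon that bears the methyl in compound 2. Compound 1 is a limit and not a number, so the true size of this step stays unknown and it can show only a direction and a minimum: the limit of < 1 ug/mL in this assay, at which 1 of the 4 values shown sits.

The compounds shown leave open whether the ring nitrogen of the pyridin-2-yl matters, which phenyl on the same aromatic carbon would test, and whether a methyl on this carbon would give a similar number. They also leave open how an amine or a carboxylic acid would read there in this assay, and whether a longer chain would follow the two aromatic-carbon steps seen so far.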